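Diaryl urea hydrazones: swapping the aryl group on the imine carbon

The compounds below may be only part of what the source reports. "The series", "measured", "known", "first", "only" and "open" are said of these compounds alone.

Measured so far in a functional assay on NCI-H460 cells (Homo sapiens) for cytotoxicity, read by MTT assay, with a stated time of 72 h; on this read-out higher numbers stand for weaker inhibition and lower numbers for stronger inhibition:
- compound 1, `CN(C)CCn1cnnc1-c1cc(Oc2ccc(NC(=O)N/N=C/c3cccc(O)c3)cc2F)ccn1`, gives 780 nM
- compound 2, `CN(C)CCn1cnnc1-c1cc(Oc2ccc(NC(=O)N/N=C/c3ccc(O)c(O)c3)cc2F)ccn1`, gives 1930 nM
- compound 3, `CN(C)CCn1cnnc1-c1cc(Oc2ccc(NC(=O)N/N=C/c3c(O)ccc4ccccc34)cc2F)ccn1`, gives 890 nM

Compound 3 stands second highest of the three numbers; it sits closest to compound 1, with a gap that lies within the scatter, and furthest from compound 2, whose number is higher by a modest margin that lies beyond the scatter.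

Compound 4, `CN(C)CCn1cnnc1-c1cc(Oc2ccc(NC(=O)N/N=C/c3c(Cl)cccc3Cl)cc2F)ccn1`, has not yet been measured. Its change from compound 3 is 2,6-dichlorophenyl in place of 2-hydroxynaphthalen-1-yl on a carbon with a double bond to nitrogen.

Within the data shown here, two measured steps bear on this same position. The step of a 1.1-fold higher number from compound 1 to compound 3 (0.06 log units; within the scatter) shows that exchanging one aryl group for another here left the number essentially unchanged. The step of a 2.2-fold lower number from compound 2 to compound 3 (0.34 log units; beyond the scatter) was a modest drop, and a 2.5-fold higher number from compound 1 to compound 2 (0.39 log units; beyond the scatter) shows that adding a hydroxy raised the number. Compound 4 carries no hydroxy at all, so a small move downward or none beyond the scatter is expected in this assay. Compound 4 is therefore estimated at 700 nM, within 300 nM to 1800 nM, an expected step of a 1.3-fold lower number from compound 3 to compound 4 (0.10 log units; within the scatter).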

Compound 4, half-maximal inhibitory concentration: 350 nM
Estimate against measurement, compound 4: 2.0-fold (0.30 log units) above; the range from low to high includes it.
By their numbers in this assay, from the lowest: compound 4; then compounds 1 and 3 (each within the scatter of the next); then compound 2.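

In this assay the step to 2,6-dichlorophenyl gives a 2.5-fold lower number from compound 3 to compound 4 (0.41 log units; beyond the scatter) and a 2.2-fold lower number from compound 1 to compound 4 (0.35 log units; beyond the scatter) and also a 5.5-fold lower number from compound 2 to compound 4 (0.74 log units; beyond the scatter), which places compound 4 lowest of the four. Among these compounds, all the earlier aryl groups on the carbon with a double bond to nitrogen carried hydroxy, so this is the first sign that a number this low at this position does not depend on a hydroxy, and that an aryl group with one aromatic ring can go lower than the hydroxynaphthalene of compound 3. No measurement offered here explains the drop. On these data alone, the exchange removes hydroxy and adds two chlorines at once, so the share of each remains unknown. As far as these compounds go, whether a plain phenyl, a phenyl carrying one chlorine, or one carrying a methoxy or an amine would behave like compound 4 remains open.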